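The source may report more compounds than this note shows. Statements on the series, on what has been measured and on what is new or still open speak of the compounds shown alone.

Measured so far in a functional assay on U2OS cells (Homo sapiens) for antiproliferative activity, read by MTT assay, with a stated time of 72 h; a lower number here means a stronger inhibitor, a higher number a weaker inhibitor:
- compound 1 `CC(C)OC1=C(C(=O)c2ccccc2)C(c2ccc(Br)cc2)N(CCCn2ccnc2)C1=O`: 24800 nM
- compound 2 `O=C(C1=C(Nc2ccc(Br)cc2)C(=O)N(CCCn2ccnc2)C1c1ccc(Br)cc1)c1ccccc1`: 13000 nM

Among the measured compounds shown here, compound 2 carries the lower of the two numbers, yet the only step on record, a 1.9-fold lower number from compound 1 to compound 2 (0.28 log units; within the scatter), stays within the scatter, so no order between the two is established.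

Compound 3 `O=C(C1=C(Nc2ccc(Cl)cc2)C(=O)N(CCCn2ccnc2)C1c1ccc(Br)cc1)c1ccccc1` differs from compound 2 by chloro in place of bromo on an aromatic carbon. For the measured compounds named here, no measured step touches a halogen exchange on this ring; the single known step concerns another position and bears little on it. The expectation in this assay is therefore a step of no change at the digits printed from compound 2 to compound 3 (within the scatter), not beyond the scatter. For compound 3 the estimate is 13000 nM, with a range from 5000 nM to 35000 nM.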

Compound 3, half-maximal inhibitory concentration: 22800 nM
Compound 3: the middle estimate sits 1.8-fold (0.24 log units) below what was measured; low and high end bracket the measured number.
By their numbers in this assay, from the lowest: compounds 2, 3 and 1 (each within the scatter of the next).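

In this assay the step of chloro in place of bromo on an aromatic carbon, a 1.8-fold higher number from compound 2 to compound 3 (0.24 log units; within the scatter), shows that this halogen exchange sets no order at this position. The step of (4-chlorophenyl)amino in place of isopropoxy, a 1.1-fold lower number from compound 1 to compound 3 (0.04 log units; within the scatter), also sets no order, so neither halogenated amino group is separated from the isopropoxy group. No independent measurement bears on these results.

From the compounds shown here alone, it remains open whether a methoxy group or a carboxylic acid in place of the halogen would give a step beyond the scatter.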